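The source may report more compounds than this note shows. Statements on the series, on what has been measured and on what is new or still open speak of the compounds shown alone.

Measured in a functional assay on MDA-MB-231 cells (Homo sapiens) for cytotoxicity, with a stated time of 48 h; on this read-out higher numbers stand for weaker inhibition and lower numbers for stronger inhibition:
Compound 1 `COc1cc(O)c(C(=O)/C=C/c2ccc(F)cc2)c(OC)c1`: > 20000 nM, a limit and not a number.
Compound 2 `COc1cc(OC)c(C(=O)/C=C/c2ccccc2SC)c(OC)c1`: 9900 nM.
Compound 3 `COc1cc(O)c(C(=O)/C=C/c2ccccc2OC)c(OC)c1`: > 20000 nM, a limit and not a number.

Compound 2 is the only one of the three that gives a number, so it stands alone on the scale. The other two results are not numbers: the limit of > 20000 nM in this assay, at which 2 of the 3 values shown sit.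

The next compound to be tested is compound 4 `COc1cc(OC)c(C(=O)/C=C/c2ccc(Cl)cc2)c(OC)c1`. It carries 4-chlorophenyl in place of 2-(methylsulfanyl)phenyl on a double-bonded chain carbon bound to a double-bonded chain carbon.

Among the measured compounds shown here, no measured step between two closely related compounds is available as a guide. In this assay, the expectation therefore starts from compound 2 at 9900 nM, and no change beyond the usual scatter is expected in either direction. The expected change is a 1.2-fold higher number from compound 2 to compound 4 (0.08 log units; within the scatter). A result reported only as a limit would not be surprising. For compound 4 the estimated value is 12000 nM, with an expected range from 5000 nM to 25000 nM.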

Compound 4, half-maximal inhibitory concentration: 8200 nM
For compound 4 the middle estimate is 1.5-fold (0.17 log units) above the measured one; the range from low to high includes it.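

In this assay, among the compounds shown here, the first measured step at this place, on a double-bonded chain carbon bound to a double-bonded chain carbon, is 4-chlorophenyl in place of 2-(methylsulfanyl)phenyl: a 1.2-fold lower number from compound 2 to compound 4 (0.08 log units; within the scatter). The exchange removes the sulfur-bearing group and brings in a chlorine-bearing one, yet compound 2 and compound 4 cannot be told apart on this read-out. Compound 4 also gives a number rather than a limit, so this pair offers a real comparison, while the other results stay outside one: the limit of > 20000 nM in this assay, at which 2 of the 4 values shown sit.

From the compounds shown here alone, whether any group at this place moves the number beyond the scatter remains open, for instance 4-(dimethylamino)phenyl or 4-carboxyphenyl. Also open, going by these compounds, is what a single exchange of a methoxy group for a hydroxy group on the shared core would do.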